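Swapping chloro for amino on the long-chain compound

The source may report more compounds than this note shows. Statements on the series, on what has been measured and on what is new or still open speak of the compounds shown alone.

Among the compounds with values here, in a functional assay on HCT-116 cells (Homo sapiens) for antiproliferative activity, read by MTT assay, with a stated time of 48 h (on this read-out higher numbers stand for weaker inhibition and lower numbers for stronger inhibition), compound 3 (`CCCCCCCCCC(CCO)n1cnc2c(Cl)ncnc21`) gives 890 nM, the only true number so far. Compound 1 (`CCCCC(CCO)n1cnc2c(N)ncnc21`) gives > 50000 nM, which is a limit. Compound 2 (`CCCCCCC(CCO)n1cnc2c(N)ncnc21`) gives > 50000 nM, also a limit. Within the data shown here, these two share (the limit of > 50000 nM in this assay, at which 2 of the 3 values shown sit), so the one measured step, a step that the two limits leave unreadable from compound 1 to compound 2, has no usable size. Compound 4 (`CCCCCCCCCC(CCO)n1cnc2c(N)ncnc21`) keeps the chain of compound 3 and differs by amino in place of chloro on an aromatic carbon. Compounds 1 and 2 carry this amino group but shorter chains, so they offer only a loose guide. The expected change is a 9.0-fold higher number from compound 3 to compound 4 (0.95 log units; beyond the scatter), toward weaker inhibition. For compound 4 the estimated value is 8000 nM, with an expected range of 1500 nM to 45000 nM.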

Compound 4, half-maximal inhibitory concentration: 10500 nM
The estimate for compound 4 lay 1.3-fold (0.12 log units) below the measured number, within the range that was stated.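

In this assay, amino and chloro can now be compared on the same long chain, and the swap gives a 12-fold higher number from compound 3 to compound 4 (1.07 log units; beyond the scatter), so at this aromatic carbon chloro is clearly the better of the two. With amino kept in place, the long chain also helps, giving an at least 4.7-fold lower number from compound 2 to compound 4 (0.67 log units; beyond the scatter) and an at least 4.7-fold lower number from compound 1 to compound 4 (0.67 log units; beyond the scatter). Those two sizes are bounds rather than exact steps, and the step between the two shorter chains cannot be read: the limit of > 50000 nM in this assay, at which 2 of the 4 values shown sit.

Still open, going by these compounds, is whether bromo or methoxy at this carbon would match chloro, and whether a longer chain would lower the number further.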